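Piperidine aorta series: loss of the cyclohexyl branch

The compounds below may be only part of what the source reports. "The series", "measured", "known", "first", "only" and "open" are said of these compounds alone.

Measured compounds in a functional assay (aorta) with Oryctolagus cuniculus as the target; a higher number here means weaker binding, a lower number tighter binding:
- compound 1, `COc1cc(C(C)=O)ccc1OCCCN1CCC(C(c2ccc(F)cc2)c2ccc(F)cc2)CC1`: 1.59 nM
- compound 2, `COc1cc(C(C)=O)ccc1OCCCN1CCC(C(c2ccc(F)cc2)c2ccc(F)c(F)c2)CC1`: 1.26 nM
- compound 3, `COc1cc(C(C)=O)ccc1OCCCN1CCC(C(c2ccc(F)cc2)C2CCCCC2)CC1`: 5.01 nM

Compound 3 stands with the highest number of the three in this assay. Its nearest neighbour is compound 1, a 3.2-fold higher number from compound 1 to compound 3 (0.50 log units; beyond the scatter); the furthest is compound 2, a 4.0-fold higher number from compound 2 to compound 3 (0.60 log units; beyond the scatter). Compound 1 and compound 2 themselves sit close together, a 1.3-fold lower number from compound 1 to compound 2 (0.10 log units; within the scatter).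

Compound 4, `COc1cc(C(C)=O)ccc1OCCCN1CCC(Cc2ccc(F)cc2)CC1`, has not been measured. The change from compound 3 is hydrogen in place of cyclohexyl on a saturated chain carbon bound to an aromatic carbon and a saturated ring carbon.

Going by the values given here, the only measured steps that touch this position are those into compound 3, a 3.2-fold higher number from compound 1 to compound 3 (0.50 log units; beyond the scatter) and a 4.0-fold higher number from compound 2 to compound 3 (0.60 log units; beyond the scatter), in which one ring-bearing group at the saturated chain carbon was exchanged for another and the number rose modestly. Among the compounds with values here, no measured step removes the group at this carbon outright, so the present change goes further than anything seen, and the steps into compound 3 can only indicate the direction. Compound 4 is expected to give a still higher number, a 10-fold higher number from compound 3 to compound 4 (1.00 log units; beyond the scatter), with wide uncertainty. The estimate for compound 4 in this assay is 50 nM, expected to fall between 10 nM and 250 nM.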

Compound 4, dissociation constant: 20 nM
The estimate for compound 4 lay 2.5-fold (0.40 log units) above the measured number; the measured number falls inside the stated range.
By their numbers in this assay, from the lowest: compounds 2 and 1 (each within the scatter of the next); then compound 3; then compound 4.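

Taking the group off entirely at the saturated chain carbon bound to an aromatic carbon and a saturated ring carbon still costs something in this assay: hydrogen in place of cyclohexyl raises the number again (a 4.0-fold higher number from compound 3 to compound 4 (0.60 log units; beyond the scatter)), so the cyclohexyl of compound 3 retains part of what the aromatic groups give. Measured against the aromatic compounds, the loss of the whole branch is large, for both the 4-fluorophenyl (a 13-fold higher number from compound 1 to compound 4 (1.10 log units; beyond the scatter)) and the 3,4-difluorophenyl (a 16-fold higher number from compound 2 to compound 4 (1.20 log units; beyond the scatter)), which sets the full span of this position at a size that the exchanges of one ring for another did not reveal. No supporting data are at hand that would explain this rise in the number at this carbon.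

Open, as far as these compounds go, is whether a methyl or an isopropyl at this carbon would give a number closer to compound 3 or to compound 4, which would show how much of the branch is needed. Also open, from the compounds shown here alone, is how an unsubstituted phenyl or a hydroxyl at the same carbon would stand against the 4-fluorophenyl of compound 1 in this assay.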